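From Hydroxy to Methoxy in an Antiproliferative Series

The source may report more compounds than this note shows. Statements on the series, on what has been measured and on what is new or still open speak of the compounds shown alone.

In a functional assay on HL-60 cells (Homo sapiens) for antiproliferative activity, with a stated time of 72 h (a lower number here means a stronger inhibitor, a higher number a weaker inhibitor), compound 1 (`COc1cc(OC)c(C(=O)/C=C/c2ccccc2Cl)c(O)c1CN1CCCC1`) gives 14200 nM. Compound 2 (`COc1cc(O)c2c(=O)cc(-c3ccccc3Cl)oc2c1CN1CCCCC1`) gives 48100 nM, the higher of the two numbers and so the weaker result, and its gap to compound 1 lies beyond the usual scatter. These two compounds differ in more than one place, so the gap cannot be tied to any single change.

Compound 3 (`COc1cc(OC)c2c(=O)cc(-c3ccccc3Cl)oc2c1CN1CCCCC1`) has not yet been measured in this assay. It departs from compound 2 at one point: methyl in place of hydrogen on an oxygen on an aromatic ring, with methyl in place of hydrogen on an oxygen on an aromatic ring, which turns hydroxy to methoxy. Among the measured compounds shown here, no measured pair here shows this change alone, so the expectation rests on thin evidence. For the measured compounds named here, with compound 2 at 48100 nM, the higher of the two numbers so far, a shift toward a lower number seems somewhat more likely than one toward a higher number. The expected step, a 1.6-fold lower number from compound 2 to compound 3 (0.21 log units; within the scatter), is small and is estimated to stay within the scatter. For compound 3 the estimated value is 30000 nM, with an expected range from 10000 nM to 90000 nM.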

Compound 3, half-maximal inhibitory concentration: 34500 nM
Estimate against measurement, compound 3: 1.2-fold (0.06 log units) below, within the range that was stated.
By their numbers in this assay, from the lowest: compound 1; then compounds 3 and 2 (each within the scatter of the next).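

Read in this assay, the change from hydroxy to methoxy now has a direct measurement, which the earlier compounds could not give since they differ in more than one place: it amounts to a 1.4-fold lower number from compound 2 to compound 3 (0.14 log units; within the scatter) and leaves compound 2 and compound 3 indistinguishable in this assay. On this oxygen on an aromatic ring, methyl in place of hydrogen is therefore tolerated, and the free hydroxy is not shown to be required for the activity seen in this pair, though that activity is modest in both compounds. Nothing available here explains why this step stays so small.

What the compounds shown leave open is whether this tolerance extends beyond a single methyl, for instance to an ethyl group, a longer chain or a chain ending in an amine on the same oxygen. Compound 1 differs from compound 3 in more than one place, so which of those differences matters in this assay also remains unresolved.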